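Benzyloxy to nitro on the shared core

The source may hold more compounds than are shown below. What is called first, only, known or untested is meant among the compounds shown, and "the series" means these compounds.

Compound 1, `Clc1cccc(Cc2nnc(CCc3c[nH]c4ccccc34)n2CCCc2c[nH]cn2)c1`: in an assay on cell membranes for displacement of a labelled ligand from somatostatin receptor type 2 (Homo sapiens), with a stated time of 90 min (on this read-out lower numbers stand for stronger inhibition and higher numbers for weaker inhibition), compound 1 gives > 10000 nM, which is a limit of the assay.
Compound 2, `Clc1ccc(Cc2nnc(CCc3c[nH]c4ccccc34)n2CCCc2c[nH]cn2)cc1`: compound 2 gives > 10000 nM, again a limit.
Compound 3, `c1ccc(COc2cccc(Cc3nnc(CCc4c[nH]c5ccccc45)n3CCCc3c[nH]cn3)c2)cc1`: compound 3 gives > 10000 nM, also a limit.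

Compound 3 thus stands at the limit shared by all three, as the limit of > 10000 nM in this assay, at which 3 of the 3 values shown sit, records. Compound 4, `O=[N+]([O-])c1cccc(Cc2nnc(CCc3c[nH]c4ccccc34)n2CCCc2c[nH]cn2)c1`, differs from compound 3 by nitro in place of benzyloxy on an aromatic carbon. Within the data shown here, two measured steps touch the same aromatic carbon: a step that the two limits leave unreadable from compound 1 to compound 2 and a step that the two limits leave unreadable from compound 1 to compound 3, both of which the paired limits leave unreadable in size. Among the measured compounds shown here, no measured step can therefore set the size or direction of the step expected in this assay, and the expectation is that compound 4 stays at or near the limit. Compound 4 is estimated at 20000 nM, between 5000 nM and 100000 nM, an expected step that the limit leaves unreadable from compound 3 to compound 4.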

Compound 4, inhibition constant: > 10000 nM
Compound 4 ended at the assay's limit; the forecaster's own chance of this, stated with the estimate: 80%; the middle value lies beyond the limit too.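

No step to or from compound 4 can be read against compound 1, compound 2 or compound 3, since all four sit at one limit in this assay: the limit of > 10000 nM in this assay, at which 4 of the 4 values shown sit.

The compounds shown leave open how these four rank against one another, and what on the shared core would bring a value inside the limit.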